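The source may report more compounds than this note shows. Statements on the series, on what has been measured and on what is new or still open speak of the compounds shown alone.

Of the compounds shown here, three built on one shared core have been measured in a functional assay on U-87MG ATCC cells (Homo sapiens) for inhibition; a higher number here means a weaker inhibitor, a lower number a stronger inhibitor. Compound 1, `COc1cc(/C=C/C(=O)c2cccc(NC(=O)c3ccco3)c2)ccc1O`, gives 6.65 ug/mL in this assay. Compound 3, `COc1cc(/C=C/C(=O)c2cccc(NC(=O)c3cccs3)c2)ccc1O`, gives 14.7 ug/mL. Compound 2, `CCOC(=O)C(=O)Nc1cccc(C(=O)/C=C/c2ccc(O)c(OC)c2)c1`, reaches only a limit of the assay, > 50 ug/mL. Of the two plain numbers, compound 3 stands highest, with compound 1 nearest; the gap between them is a 2.2-fold higher number from compound 1 to compound 3 (0.34 log units; beyond the scatter), modest but beyond the scatter.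

Compound 4, `CCCC(=O)Nc1cccc(C(=O)/C=C/c2ccc(O)c(OC)c2)c1`, has not yet been measured. It differs from compound 3 in one place: propyl in place of thiophen-2-yl on a carbonyl carbon. Among the compounds with values here, two measured steps concern this same carbonyl carbon. Thiophen-2-yl in place of furan-2-yl gave a 2.2-fold higher number from compound 1 to compound 3 (0.34 log units; beyond the scatter). Ethoxycarbonyl in place of furan-2-yl gave an at least 7.5-fold higher number from compound 1 to compound 2 (0.87 log units; beyond the scatter), and an at least 3.4-fold lower number from compound 2 to compound 3 (0.53 log units; beyond the scatter) shows the same pair from the other side. Within the data shown here, no measured step replaces the ring with a chain, so the direction rests on the pattern that both ring groups give numbers while the non-ring group gives a limit. Compound 4 is therefore expected to show a step of a 1.7-fold higher number from compound 3 to compound 4 (0.23 log units; within the scatter), toward a weaker inhibitor. Compound 4 is estimated to give about 25 ug/mL, with a likely range from 10 ug/mL to 60 ug/mL.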

Compound 4, half-maximal inhibitory concentration: 5.56 ug/mL
For compound 4 the middle estimate is 4.5-fold (0.65 log units) above the measured one; the measured number lies below the stated range.
By their numbers in this assay, from the lowest: compounds 4 and 1 (each within the scatter of the next); then compound 3. At a limit, above all of these: compound 2.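

In this assay, this carbonyl carbon does not need a ring to give a measurable number: propyl in place of thiophen-2-yl gives a 2.6-fold lower number from compound 3 to compound 4 (0.42 log units; beyond the scatter), while propyl in place of furan-2-yl gives a 1.2-fold lower number from compound 1 to compound 4 (0.08 log units; within the scatter), so compound 4 and compound 1 cannot be told apart. The earlier contrast between the two ring groups and ethoxycarbonyl therefore does not separate rings from all non-ring groups, since propyl in place of ethoxycarbonyl gives an at least 8.9-fold lower number from compound 2 to compound 4 (0.95 log units; beyond the scatter). Compound 2 remains the only compound at a limit, which is not a plain number: the limit of > 50 ug/mL in this assay, at which 1 of the 4 values shown sits.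

On these data alone, it remains open whether a longer chain such as pentyl, or a chain carrying an amine or a carboxylic acid, would give a number like that of compound 4. As far as these compounds go, what separates ethoxycarbonyl from propyl also remains open.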